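This account rests on a few compounds, and the source may have more. Where it says the series, first, only, none or still open, it means among the compounds named here.

Measured so far in a toxicity assay on L02 cells (Homo sapiens) for cytotoxicity, read by MTT assay, with a stated time of 72 h; on this read-out higher numbers stand for weaker inhibition and lower numbers for stronger inhibition:
- compound 1 (`CC1(C)OC[C@@H](Cn2cc(Cn3c4c(c5ccccc53)C(=O)c3c[n+]([O-])c5ccccc5c3C4=O)nn2)O1`): 2900 nM 
- compound 2 (`O=C1c2c[n+]([O-])c3ccccc3c2C(=O)c2c1c1ccccc1n2CCCCN1CCCCC1`): 610 nM 
- compound 3 (`O=C1c2c[n+]([O-])c3ccccc3c2C(=O)c2c1c1ccccc1n2Cc1cn([C@H]2C[C@H](O)[C@@H](CO)O2)nn1`): 280 nM 

Compound 2 sits in the middle of these three numbers, with compound 3 lower and compound 1 higher. Compound 4 (`CN1CCN(CCCCCn2c3c(c4ccccc42)C(=O)c2c[n+]([O-])c4ccccc4c2C3=O)CC1`) differs from compound 2 as follows: (4-methylpiperazin-1-yl)methyl in place of piperidin-1-yl on a saturated chain carbon, four bonds along the chain from an aromatic nitrogen. For the measured compounds named here, no measured step covers this exchange. Going by the values given here, the only step available, a 10-fold lower number from compound 1 to compound 3 (1.02 log units; beyond the scatter), was large but concerns other groups, so it shows how far numbers here can differ and gives no size for this change. Compound 2 (610 nM) is therefore the anchor in this assay, and no step beyond the scatter is expected, the estimated one being a 1.2-fold higher number from compound 2 to compound 4 (0.09 log units; within the scatter) and its direction uncertain. For compound 4 the estimate is 750 nM within an expected range from 270 nM to 2100 nM here.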

Compound 4, half-maximal inhibitory concentration: 1640 nM
Compound 4: middle estimate off by 2.2-fold (0.34 log units), on the low side; low and high end bracket the measured number.
By their numbers in this assay, from the lowest: compound 3; then compound 2; then compounds 4 and 1 (each within the scatter of the next).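

In this assay, the exchange at this place is not neutral: a 2.7-fold higher number from compound 2 to compound 4 (0.43 log units; beyond the scatter), a modest step beyond the scatter and the first measured size for (4-methylpiperazin-1-yl)methyl in place of piperidin-1-yl. Nothing available bears on the reason for this step.

As far as these compounds go, the ring and the chain length change together in this pair, so the share of each in the step stays open. Also open, from the compounds shown here alone, is how a morpholine ring or a primary amine would read in place of these rings.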